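The compounds below may be only part of what the source reports. "The series", "measured", "known", "first", "only" and "open" are said of these compounds alone.

Measured in an ADME assay on a cell-free system (plasma, Homo sapiens) for metabolic stability; on this read-out higher numbers stand for a longer-lived compound and lower numbers for a shorter-lived compound:
- compound 1 `CS(=O)(=O)N(COC(=O)c1ccccc1)c1ccc([N+](=O)[O-])cc1Oc1ccccc1`: 0.0322 h
- compound 2 `CCCSc1ccc2nc(NC(=O)OC)n(C(=O)OCC)c2c1`: 0.12 h

Compound 1, at 0.0322 h, holds the lower of the two numbers, and the gap up to compound 2 lies beyond the usual scatter. Compound 3 `CCOC(=O)CNC(=O)OCN(c1ccc([N+](=O)[O-])cc1Oc1ccccc1)S(C)(=O)=O` keeps the core of compound 1 and changes one group: ((ethoxycarbonyl)methyl)amino in place of phenyl on a carbonyl carbon. In words, ((ethoxycarbonyl)methyl)amino stands in place of phenyl on a carbonyl carbon, so benzoyloxy becomes (((ethoxycarbonyl)methyl)carbamoyl)oxy. Going by the values given here, no measured pair shows this change, so the direction is a judgement and the range must stay wide. With compound 1 at the bottom of a very short set, a moderately longer life seems the likelier outcome. The expected step is a 9.3-fold higher number from compound 1 to compound 3 (0.97 log units; beyond the scatter). For compound 3 the estimated half-life is 0.3 h, with an expected range of 0.07 h to 1.5 h.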

Compound 3, half-life: 15.9 h
For compound 3 the middle estimate is 53-fold (1.72 log units) below the measured one; the whole stated range lies below it.
By their numbers in this assay, from the lowest: compound 1; then compound 2; then compound 3.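

In this assay, the group on this carbonyl carbon proves to matter greatly: with the rest of compound 1 unchanged, ((ethoxycarbonyl)methyl)amino in place of phenyl gives a 490-fold higher number from compound 1 to compound 3 (2.69 log units; beyond the scatter), a large step well beyond the scatter. The change from benzoyloxy to (((ethoxycarbonyl)methyl)carbamoyl)oxy therefore shows that this one place can, on its own, move the half-life a long way. Nothing available explains why the number moves this far.

As far as these compounds go, it remains open which part of the entering group carries the step, since the ring leaves while the amino nitrogen and the ethoxycarbonyl end enter together. Methylamino or (carboxymethyl)amino on the same carbonyl carbon would help separate these parts.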